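A Halogen Swap on the Triazole Phenyl of Compound 2

A few compounds are considered here, and "the series" means these few. Any claim that something is new, unique, unknown or untested is made for them only; others in the source may bear on it.

Compound 1 `C=C1C[C@]23C[C@@]1(O)CC[C@@H]2c1cccc(C)c1[C@@H]3Cn1cc(-c2ccccc2)nn1`: > 20000 nM
Compound 2 `C=C1C(=O)[C@]23C[C@@]1(O)CC[C@H]2c1ccc(OS(=O)(=O)c2ccc(C)cc2)c(C)c1[C@@H]3Cn1cc(-c2ccc(F)cc2)nn1`: 1630 nM
Compound 3 `Cc1ccc(S(=O)(=O)Oc2ccc3c(c2C)[C@H](Cn2cc(-c4ccc(Cl)cc4)nn2)[C@@]24CC(=O)[C@@](C)(CC[C@@H]32)C4)cc1`: > 20000 nM

The three compounds were tested in a functional assay on SW480 cells (Homo sapiens) for cytotoxicity, read by MTT assay, with a stated time of 4 days; a lower number here means a stronger inhibitor, a higher number a weaker inhibitor. Compound 1 reaches only the limit of the assay at > 20000 nM. Compound 3 likewise reaches only the limit at > 20000 nM. For the measured compounds named here, compound 2 is the one compound of the three with a numerical reading, giving 1630 nM in this assay. The other two readings sit at the limit of > 20000 nM in this assay, at which 2 of the 3 values shown sit, so no comparison between compound 2 and either of them can be put into a size.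

Compound 4 `C=C1C(=O)[C@]23C[C@@]1(O)CC[C@H]2c1ccc(OS(=O)(=O)c2ccc(C)cc2)c(C)c1[C@@H]3Cn1cc(-c2ccc(Cl)cc2)nn1` has not yet been measured in this assay. It differs from compound 2 in one place: chloro in place of fluoro on an aromatic carbon. Both compounds keep the same core with the ketone and the exocyclic methylene, the tosylate and the triazole, and only the halogen at the far end of the phenyl ring changes.

Going by the values given here, no pair of measured compounds here differs in a single place, so there is no measured step to lean on. The change from compound 2 to compound 4 is a single halogen for another. A step of no more than the usual scatter is expected in this assay, with no firm direction. Compound 4 is therefore estimated at 1300 nM, within 450 nM to 4000 nM, which is the expected step of a 1.3-fold lower number from compound 2 to compound 4 (0.10 log units; within the scatter).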

Compound 4, half-maximal inhibitory concentration: 2390 nM
Estimate against measurement, compound 4: 1.8-fold (0.26 log units) below, within the range that was stated.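

In this assay, the change from 4-fluorophenyl to 4-chlorophenyl gives a 1.5-fold higher number from compound 2 to compound 4 (0.17 log units; within the scatter). For the compounds shown here, this is the first step in the set that can be read between compounds differing in one place, and it shows that at this aromatic carbon, para to a large group, the assay does not tell fluoro from chloro. Compound 4 also gives the shared core with the ketone, the exocyclic methylene and the tosylate a second numerical reading beside compound 2, while no steps to the other two compounds can be read, and nothing shown here bears on why the two halogens read alike.

The compounds shown leave open whether this position accepts anything beyond a single halogen atom, such as a methoxy group, an amine, a carboxylic acid or a longer chain like butyl, any of which would test it far harder than this swap did. Going by these compounds alone, they also leave open how much the ketone, the exocyclic methylene and the tosylate each contribute, as no step isolates any one of them.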